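A few compounds are considered here, and "the series" means these few. Any claim that something is new, unique, unknown or untested is made for them only; others in the source may bear on it.

Compound 1 `CS(=O)(=O)CCn1c(Cn2cc(S(C)(=O)=O)c3ccccc32)nc2cc(Cl)ccc21`: in an ADME assay on HEp-2 cells (Homo sapiens) for cytotoxicity, with a stated time of 4 days (a lower number here means that less compound is tolerated, a higher number that more compound is tolerated), compound 1 gives > 100000 nM, which is a limit of the assay.
Compound 2 `CC(C)S(=O)(=O)c1cn(Cc2nc3cc(Cl)ccc3n2CCCS(C)(=O)=O)c2ccccc12`: in this assay compound 2 gives > 100000 nM, again a limit of the assay.
Compound 3 `CS(=O)(=O)c1nn(Cc2nc3cc(Cl)ccc3n2CCCO)c2cnccc12`: in this assay compound 3 gives > 100000 nM, once more a limit of the assay.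

Compound 3 therefore stands where all three values sit, at the limit of > 100000 nM in this assay, at which 3 of the 3 values shown sit, and no number sets it apart from the other two. Compound 4 `CC(C)(CO)Cn1c(Cn2nc(S(C)(=O)=O)c3ccncc32)nc2cc(Cl)ccc21` differs from compound 3 by a single change: 1-(hydroxymethyl)-1-methylethyl in place of 2-hydroxyethyl on a saturated chain carbon bound to an aromatic nitrogen. Among the measured compounds shown here, no measured pair shows this change, so its effect in this assay is open. The step is expected to be a number no higher from compound 3 to compound 4 (the limit leaves the size open), nothing beyond the scatter in either direction, because compound 3 already reaches > 100000 nM. Compound 4 is expected to give 100000 nM, within a range from 60000 nM to 200000 nM, most likely reported only as a limit.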

Compound 4, half-maximal cytotoxic concentration: > 100000 nM
Compound 4 gave a limit, no number (the forecaster's own chance of this, stated with the estimate: 85%); the middle value sits exactly at the limit.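

Compound 3 and compound 4 both stop at a limit of this assay, so no step between them can be read: the limit of > 100000 nM in this assay, at which 4 of the 4 values shown sit.

The concentration at which any of these compounds becomes toxic to the cells remains open.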